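The source may report more compounds than this note shows. Statements on the series, on what has been measured and on what is new or still open speak of the compounds shown alone.

Compound 1 `CN(C[C@H]1Cc2c(cccc2N2CCN(C3COC3)CC2)CN1)[C@H]1CCCc2cccnc21`: in a functional assay on CCRF-CEM cells for antagonist activity at C-X-C chemokine receptor type 4 (Homo sapiens), read by calcium flux, with stated times of 25 min and 90 s (a lower number here means a stronger inhibitor, a higher number a weaker inhibitor), compound 1 gives 381 nM.
Compound 2 `CC(C)N1CCN(c2cccc3c2C[C@H](CN(C)[C@H]2CCCc4cccnc42)NC3)CC1`: in this assay compound 2 gives 16.9 nM.
Compound 3 `CC(C)N(C[C@H]1Cc2c(cccc2N2CCNCC2)CN1)[C@H]1CCCc2cccnc21`: in this assay compound 3 gives 364 nM.

Compound 3 stands second highest of the three numbers; its value and that of compound 1 lie within the scatter of each other, while compound 2 sits well apart, as a 23-fold lower number from compound 1 to compound 2 (1.35 log units; beyond the scatter) shows for the related pair.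

Compound 4 `CN(C[C@H]1Cc2c(cccc2N2CCNCC2)CN1)[C@H]1CCCc2cccnc21` is not yet measured. It differs from compound 3 in one place: methyl in place of isopropyl on an amine nitrogen. Among the measured compounds shown here, the only measured step, a 23-fold lower number from compound 1 to compound 2 (1.35 log units; beyond the scatter), concerns the amine nitrogen in the ring, not the amine nitrogen changed here, so no measured step bears directly on this change. Compound 1, which carries the same methyl as compound 4, and compound 3, which carries the isopropyl, give numbers within the scatter of each other, though their rings differ too. The expected step is therefore a 1.1-fold lower number from compound 3 to compound 4 (0.04 log units; within the scatter), nothing beyond the scatter. Compound 4 is estimated at 330 nM, within 110 nM to 1000 nM.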

Compound 4, half-maximal inhibitory concentration: 6.08 nM
The estimate for compound 4 lay 54-fold (1.73 log units) above the measured number; measured number outside the range, below it.
By their numbers in this assay, from the lowest: compound 4; then compound 2; then compounds 3 and 1 (each within the scatter of the next).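

In this assay, methyl in place of isopropyl on the amine nitrogen whose other neighbours are a saturated chain carbon and a saturated ring carbon brings a 60-fold lower number from compound 3 to compound 4 (1.78 log units; beyond the scatter) and shows that this position responds very strongly to a small change in its group. The earlier compounds shown here offered no direct test of this position. With methyl kept there, hydrogen on the amine nitrogen in the ring gives a 2.8-fold lower number from compound 2 to compound 4 (0.44 log units; beyond the scatter) in place of isopropyl and a 63-fold lower number from compound 1 to compound 4 (1.80 log units; beyond the scatter) in place of oxetan-3-yl, which makes compound 4 the strongest inhibitor of the four.

Going by these compounds, it remains open where ethyl or hydrogen on the first amine nitrogen would fall, and whether the swap from isopropyl to methyl has the same effect with isopropyl on the ring nitrogen. Nothing shown here explains the size of these steps.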